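This account rests on a few compounds, and the source may have more. Where it says the series, first, only, none or still open, it means among the compounds named here.

Working notes on the series. Three ureas on a shared core have been measured in a functional assay on NCI-H23 cells (Homo sapiens) for inhibition, read by sulforhodamine B assay, with a stated time of 48 h; a higher number here means a weaker inhibitor of growth, a lower number a stronger inhibitor of growth. Compound 1 `COc1cc(-c2nn(-c3cccc(NC(=O)Nc4cc(C(F)(F)F)cc(C(F)(F)F)c4)c3)cc2-c2ccncc2)ccc1Cl` gives 1090 nM. Compound 2 `O=C(Nc1cccc(-n2cc(-c3ccncc3)c(-c3ccc(Cl)c(O)c3)n2)c1)Nc1cc(C(F)(F)F)cc(C(F)(F)F)c1` carries hydrogen in place of methyl on an oxygen on an aromatic ring, and in this assay compound 2 gives 1020 nM; the step is a 1.1-fold lower number from compound 1 to compound 2 (0.03 log units; within the scatter). Compound 3 `COc1cc(-c2nn(-c3cccc(NC(=O)Nc4ccc(Cl)c(C(F)(F)F)c4)c3)cc2-c2ccncc2)ccc1Cl` differs from compound 1 in the urea part; the difference between the two cores is not broken down here. In this assay compound 3 gives 1310 nM. Set against compound 1 and compound 2, the number of compound 3 lies within the scatter of both, so no order among the three can be drawn.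

Compound 4 `O=C(Nc1cccc(-n2cc(-c3ccncc3)c(-c3ccc(Cl)c(O)c3)n2)c1)Nc1ccc(Cl)c(C(F)(F)F)c1` is not yet measured. It relates to compound 3 as compound 2 relates to compound 1: hydrogen in place of methyl on an oxygen on an aromatic ring. Both changes sit at the same place, an oxygen on an aromatic ring whose other neighbours are aromatic carbon, so this is the same change. Going by the values given here, the only precedent, a 1.1-fold lower number from compound 1 to compound 2 (0.03 log units; within the scatter), stayed within the scatter. The step from compound 3 to compound 4 is therefore expected to be small, a 1.1-fold lower number from compound 3 to compound 4 (0.04 log units; within the scatter), resting on a 1.1-fold lower number from compound 1 to compound 2 (0.03 log units; within the scatter). The estimate for compound 4 in this assay is 1200 nM, expected to fall between 600 nM and 2400 nM.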

Compound 4, concentration for 50% growth inhibition: 951 nM
Estimate against measurement, compound 4: 1.3-fold (0.10 log units) above; the range from low to high includes it.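

In this assay, methoxy to hydroxy on the 4-chloro-3-methoxyphenyl group gives a 1.4-fold lower number from compound 3 to compound 4 (0.14 log units; within the scatter), and this step can be set beside the earlier one on the other urea: the same change on two cores in this assay, a 1.1-fold lower number (0.03 log units; within the scatter) from compound 1 to compound 2 and a 1.4-fold lower number (0.14 log units; within the scatter) from compound 3 to compound 4, 1.3-fold (0.11 log units) apart, within the scatter of two such steps. The change therefore carries across these two cores with no readable difference between the steps, and on both it stays within the scatter. This does not show that the hydroxy compounds differ from their methoxy partners in either direction, and two cores that differ only in the urea part say nothing about how the change would behave on a core altered elsewhere.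

The compounds shown leave open what an ethyl group or a longer chain on that oxygen would do, or an amine in place of the hydroxy. Also open, from the compounds shown here alone, is how the same change reads on a urea part carrying a carboxylic acid or a nitrile instead of trifluoromethyl.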